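Flipping One Hydroxyl Stereocentre in a Prostaglandin Analogue

The source may hold more compounds than are shown below. What is called first, only, known or untested is meant among the compounds shown, and "the series" means these compounds.

Compound 1 `CCCCC[C@@H](O)/C=C/[C@H]1OC[C@H](O)[C@@H]1C/C=C\CCCC(=O)O` registers in a functional assay on NIH3T3 cells (Mus musculus) for activation of prostaglandin F2-alpha receptor (Homo sapiens), read by inositol phosphate accumulation (a lower number here means that less compound is needed, a higher number that more compound is needed for the effect), only as a limit, > 10000 nM, and the limit of > 10000 nM in this assay, at which 1 of the 2 values shown sits, therefore carries no number. Within the data shown here, compound 2 `O=C(O)CCCC/C=C\C[C@H]1[C@@H](O)CO[C@@H]1/C=C/[C@@H](O)COc1cccc(C(F)(F)F)c1` gives 187 nM in this assay, the only true number available here. Compound 3 `O=C(O)CCCC/C=C\C[C@H]1[C@@H](O)CO[C@@H]1/C=C/[C@H](O)COc1cccc(C(F)(F)F)c1` differs from compound 2 in that (the two compounds have the same atoms and bonds and differ only in configuration as drawn: 1 of 6 stereo elements differ; a stereocentre at a saturated chain carbon is drawn R in compound 2 and S in compound 3). Among the measured compounds shown here, no measured pair shows what such a change does, so the expected step from compound 2 to compound 3, an 11-fold higher number from compound 2 to compound 3 (1.03 log units; beyond the scatter), is an estimate leaning toward weaker activation, beyond the usual scatter. Compound 3 is expected to sit near 2000 nM, within 400 nM to 10000 nM.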

Compound 3, half-maximal effective concentration: 899 nM
Compound 3: the middle estimate sits 2.2-fold (0.35 log units) above what was measured, and the stated range covers the measured number.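

The mirror-image drawing of a single saturated chain carbon is enough to shift activation in this assay: going from R to S gives a 4.8-fold higher number from compound 2 to compound 3 (0.68 log units; beyond the scatter). That shift can be pinned on this one stereocentre alone because no atom or bond changes: the fact that compounds 2 and 3 differ only in the configuration as drawn

The activation also survives the flip, since compound 3 still gives a measured value of 899 nM. Still open, from the compounds shown here alone, is whether a ketone in place of this hydroxyl would keep activation. Going by these compounds, it is also open whether the same flip would have a similar effect with a chlorine in place of the trifluoromethyl.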